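Trimming the piperazine: solubility expectations for compound 3

The source may report more compounds than this note shows. Statements on the series, on what has been measured and on what is new or still open speak of the compounds shown alone.

Compound 1 `CN1CCN(CCCS(=O)(=O)c2ccc3nc(NC(=O)NC(=O)c4ccccc4Cl)sc3c2)CC1` stands highest of the two numbers shown: in a physicochemical assay for solubility, at pH 7.4 (on this read-out higher numbers stand for higher solubility and lower numbers for lower solubility), compound 1 gives 280000 nM, while compound 2 `CC(C)NCCS(=O)(=O)c1ccc2nc(NC(=O)NC(=O)c3ccccc3Cl)sc2c1` gives 71000 nM, the step being a 3.9-fold lower number from compound 1 to compound 2 (0.60 log units; beyond the scatter). Compound 3 `CN(C)CCCS(=O)(=O)c1ccc2nc(NC(=O)NC(=O)c3ccccc3Cl)sc2c1` differs from compound 1 by dimethylamino in place of 4-methylpiperazin-1-yl on a saturated chain carbon, three bonds along the chain from a sulfonyl sulfur. Among the measured compounds shown here, the only step on record that replaces the 4-methylpiperazin-1-yl unit with a group having no ring is a 3.9-fold lower number from compound 1 to compound 2 (0.60 log units; beyond the scatter), and it points downward in this assay. A lowering of similar or somewhat smaller size is therefore expected for compound 3, a 2.2-fold lower number from compound 1 to compound 3 (0.33 log units; beyond the scatter). Compound 3 is accordingly estimated at 130000 nM, with a range from 50000 nM to 300000 nM.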

Compound 3, solubility: 240000 nM
Estimate against measurement, compound 3: 1.8-fold (0.27 log units) below, and the stated range covers the measured number.
By their numbers in this assay, from the lowest: compound 2; then compounds 3 and 1 (each within the scatter of the next).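

In this assay, dimethylamino can stand in place of 4-methylpiperazin-1-yl, three bonds along the chain from a sulfonyl sulfur, with no change beyond the scatter (a 1.2-fold lower number from compound 1 to compound 3 (0.07 log units; within the scatter)), so losing the ring does not by itself bring the lower number seen for compound 2. Among the compounds shown here, the step that lies beyond the scatter is instead the one that exchanges isopropylamino for (dimethylamino)methyl (a 3.4-fold higher number from compound 2 to compound 3 (0.53 log units; beyond the scatter)). Nothing measured here accounts for this difference.

That last step alters the amine and the chain together, and the compounds shown do not separate the two. As far as these compounds go, how a morpholine would read at this place also remains open.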